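The source may hold more compounds than are shown below. What is called first, only, known or untested is meant among the compounds shown, and "the series" means these compounds.

Measured compounds, with their half-maximal inhibitory concentrations:

- compound 1 `O=C(CCCc1ccccc1)Nc1nc2ccccc2c(=O)s1` gives 186 nM
- compound 2 `O=C(CCc1ccccc1Br)Nc1nc2ccccc2c(=O)s1` gives 64 nM

In an assay on mitochondria (strain Sprague-Dawley) for inhibition of Amine oxidase [flavin-containing] B (Rattus norvegicus), read by fluorescence and Amplex Red, with stated times of 30 min and 45 min (a higher number here means a weaker inhibitor, a lower number a stronger inhibitor), compound 1 stands highest of the two numbers shown, that is, it is the weaker inhibitor of the pair; its nearest neighbour is compound 2, and the step of a 2.9-fold lower number from compound 1 to compound 2 (0.46 log units; beyond the scatter) is modest but beyond the usual scatter. That step alters the chain end of the molecule, swapping one aromatic group for another, while leaving the shared core untouched.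

Compound 3 `O=C(CCCc1ccccc1)Nc1nc2cc(Cl)ccc2c(=O)s1` has not yet been measured. It differs from compound 1 in a single place: chloro in place of hydrogen on an aromatic carbon. For the measured compounds named here, the change sits on the fused bicyclic core of compound 1, not on the chain, so the one measured step says nothing direct about it. Going by the values given here, with no comparable step to lean on, the expectation for compound 3 in this assay is a number close to that of compound 1, with the step of a 1.2-fold lower number from compound 1 to compound 3 (0.07 log units; within the scatter) expected to stay within the scatter, though a wide range must be allowed. The estimate for compound 3 is therefore 160 nM, between 45 nM and 550 nM.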

Compound 3, half-maximal inhibitory concentration: 1220 nM
Compound 3: middle estimate off by 7.6-fold (0.88 log units), on the low side; measured number outside the range, above it.
By their numbers in this assay, from the lowest: compound 2; then compound 1; then compound 3.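

In this assay, the shared core proves sensitive to a small change: chloro in place of hydrogen on an aromatic carbon gives a 6.6-fold higher number from compound 1 to compound 3 (0.82 log units; beyond the scatter), so compound 3 is the weaker inhibitor of this pair. For the compounds shown here, the one earlier step concerned only the chain, whereas this step shows that a single added atom on the six-membered aromatic ring of carbon only, meta to a fused ring and para to a fused ring, can shift the number beyond the scatter, and here it does so in the unfavourable direction. Nothing available explains this loss of inhibition.

As far as these compounds go, it remains open whether the loss is specific to chloro or would also appear with another group at this carbon, such as a fluorine atom, a methyl or a methoxy. It is also unknown whether chloro would give a similar step on the other aromatic carbons of the core, or when the chain carries the 2-bromophenyl group of compound 2 instead of the chain of compound 1.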